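Carboxy in place of hydroxyethyl on the shared core

This account rests on a few compounds, and the source may have more. Where it says the series, first, only, none or still open, it means among the compounds named here.

Measured so far in an assay on isolated protein for inhibition of protein kinase C epsilon type (Homo sapiens), read by coupled enzyme assay; on this read-out higher numbers stand for weaker inhibition and lower numbers for stronger inhibition:
compound 1 `C[C@H](O)Cc1cc(-c2ccnc3[nH]nc(C(F)(F)F)c23)cc(C2(C#N)CC2)c1` gives 51 nM
compound 2 `CCC(O)Cc1cc(-c2ccnc3[nH]nc(C(F)(F)F)c23)cc(C2(C#N)CC2)c1` gives 49 nM
compound 3 `CC(=O)OCCc1cc(-c2ccnc3[nH]nc(C(F)(F)F)c23)cc(C2(C#N)CC2)c1` gives 119 nM

Compound 1 stands second highest of the three numbers. Its nearest neighbour is compound 2: the step of a 1.0-fold lower number from compound 1 to compound 2 (0.02 log units; within the scatter) lies within the scatter, so the two are not separable on this read-out. Among the compounds with values here, the steps of a 2.3-fold higher number from compound 1 to compound 3 (0.37 log units; beyond the scatter) and a 2.4-fold higher number from compound 2 to compound 3 (0.39 log units; beyond the scatter) are modest but beyond the scatter, and together they mark the only direction of change seen so far.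

Compound 4 `N#CC1(c2cc(CC(=O)O)cc(-c3ccnc4[nH]nc(C(F)(F)F)c34)c2)CC1` is not yet measured. It differs from compound 1 as carboxy in place of 1-hydroxyethyl on a saturated chain carbon bound to an aromatic carbon. Within the data shown here, no measured pair makes this exchange. The step that bears on it most closely is a 2.3-fold higher number from compound 1 to compound 3 (0.37 log units; beyond the scatter), where the 1-hydroxyethyl group was also given up, at a modest cost; the step of a 1.0-fold lower number from compound 1 to compound 2 (0.02 log units; within the scatter) shows that keeping a hydroxyl on the chain leaves the number unchanged. Among the measured compounds shown here, on that basis a modest rise in this assay is expected for compound 4, of about the size seen for compound 3, with wide uncertainty since the carboxy group has no precedent here. Compound 4 is therefore estimated at 110 nM, within a range of 40 nM to 350 nM. This estimate corresponds to an expected step of a 2.2-fold higher number from compound 1 to compound 4 (0.33 log units; beyond the scatter).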

Compound 4, inhibition constant: 446 nM
Beside the measured number, compound 4's estimate is 4.1-fold (0.61 log units) below it; measured number outside the range, above it.
By their numbers in this assay, from the lowest: compounds 2 and 1 (each within the scatter of the next); then compound 3; then compound 4.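

In this assay, this place on a saturated chain carbon bound to an aromatic carbon proves more sensitive than compounds 1 to 3 suggested: carboxy in place of 1-hydroxyethyl gives an 8.7-fold higher number from compound 1 to compound 4 (0.94 log units; beyond the scatter), and carboxy in place of 1-hydroxypropyl gives a 9.1-fold higher number from compound 2 to compound 4 (0.96 log units; beyond the scatter), both larger than any earlier step in the series. Giving up the hydroxyl-bearing chain does not by itself set the size of the change, as carboxy in place of acetoxymethyl still gives a 3.7-fold higher number from compound 3 to compound 4 (0.57 log units; beyond the scatter), which leaves compound 4 the weakest of the four. No measurement is available that accounts for the size of these steps.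

Still open, as far as these compounds go, is whether the rise in the number belongs to the carboxy group itself or would also appear with a primary amide or a methyl ester at this place. The compounds shown also leave open how an amine, or a carboxylic acid on a longer chain, would read on this assay, so the limits of what this place tolerates remain undefined.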